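Swapping a Cyclohexyl for a Short Alkenyl Chain

The source may hold more compounds than are shown below. What is called first, only, known or untested is meant among the compounds shown, and "the series" means these compounds.

Measured compounds:
- compound 1, `COc1cc(Cc2nc3c(N)ncnc3n2CC2CCCCC2)cc(OC)c1OC`: 39800 nM
- compound 2, `CCC(CC)Cn1c(Cc2cc(OC)c(OC)c(OC)c2)nc2c(N)ncnc21`: 158000 nM
- compound 3, `CCCCn1c(Cc2cc(OC)c(OC)c(OC)c2Br)nc2c(N)ncnc21`: 25100 nM

These three compounds share one core and differ mainly in the group attached to the aromatic nitrogen. In a functional assay on MCF7 cells (Homo sapiens) for antiproliferative activity (on this read-out lower numbers stand for stronger inhibition and higher numbers for weaker inhibition), compound 1 gives 39800 nM, the second highest of the three numbers. Compound 3 gives 25100 nM, within the scatter of compound 1, while compound 2 gives 158000 nM, a step of a 4.0-fold higher number from compound 1 to compound 2 (0.60 log units; beyond the scatter), which is beyond the scatter.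

Compound 4, `C/C=C/Cn1c(Cc2cc(OC)c(OC)c(OC)c2)nc2c(N)ncnc21`, has not yet been measured. Its change from compound 1 is prop-1-en-1-yl in place of cyclohexyl on a saturated chain carbon bound to an aromatic nitrogen. Among the compounds with values here, the only single-point step that bears on it, from compound 1 to compound 2, replaced the ring with a branched chain and weakened inhibition modestly. Compound 4 carries a short unbranched chain instead, so the direction is uncertain; no step beyond the scatter is expected. Compound 4 is therefore estimated at 45000 nM (range 15000 nM to 130000 nM), meaning an expected step of a 1.1-fold higher number from compound 1 to compound 4 (0.05 log units; within the scatter).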

Compound 4, half-maximal inhibitory concentration: 51300 nM
Estimate against measurement, compound 4: 1.1-fold (0.06 log units) below, and the stated range covers the measured number.
By their numbers in this assay, from the lowest: compounds 3, 1 and 4 (each within the scatter of the next, the first and the last beyond it); then compound 2.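

In this assay, exchanging the cyclohexyl for the open prop-1-en-1-yl, which has 3 carbons in place of 6 and no ring, gives a difference that stays within the scatter (a 1.3-fold higher number from compound 1 to compound 4 (0.11 log units; within the scatter)). On a saturated chain carbon bound to an aromatic nitrogen, the ring is therefore not required to keep this level of inhibition. The step from the pentan-3-yl (a 3.1-fold lower number from compound 2 to compound 4 (0.49 log units; beyond the scatter)) also shows that open chains at this position do not all behave alike, although no available data explain why.

From the compounds shown here alone, because the pentan-3-yl and prop-1-en-1-yl groups differ in both shape and the double bond, the contribution of each feature remains open. So does the effect of a longer chain such as octyl, or of a chain ending in an amine or a carboxylic acid.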